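This account rests on a few compounds, and the source may have more. Where it says the series, first, only, none or still open, it means among the compounds named here.

In a functional assay on SH-SY5Y cells (Homo sapiens) for cytotoxicity, read by MTT assay, with a stated time of 48 h (on this read-out higher numbers stand for weaker inhibition and lower numbers for stronger inhibition), compound 1 `COc1cc(/C=C/C(=O)/C=C/c2nc3ccccc3n2C)ccc1O` gives 4700 nM. Compound 2 `COc1cc(/C=C/C(=O)/C=C/c2nc3cc(C)ccc3n2C)ccc1O` gives 4700 nM, level with compound 1. Compound 3 `COc1ccc2c(c1)nc(/C=C/C(=O)/C=C/c1ccc(O)c(OC)c1)n2C` has methoxy in place of methyl on an aromatic carbon. For the measured compounds named here, the only measured step, no change at the digits printed from compound 1 to compound 2 (within the scatter), puts methyl in place of hydrogen on an aromatic carbon and stays within the scatter. It is a different exchange, so it bears only loosely on this one, and no data yet cover methoxy on the shared core. No shift beyond the scatter is therefore expected in this assay, in either direction. The expected step is no change at the digits printed from compound 2 to compound 3 (within the scatter). The estimate for compound 3 is 4700 nM, with an expected range of 2000 nM to 11000 nM.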

Compound 3, half-maximal inhibitory concentration: 4800 nM
Compound 3: the middle estimate sits 1.0-fold (0.01 log units) below what was measured; the measured number falls inside the stated range.
By their numbers in this assay, from the lowest: compounds 1, 2 and 3 (each within the scatter of the next).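

In this assay this aromatic carbon of the shared core now carries hydrogen, methyl or methoxy without separation: the exchange to methoxy gives a 1.0-fold higher number from compound 2 to compound 3 (0.01 log units; within the scatter) and, counted from hydrogen, a 1.0-fold higher number from compound 1 to compound 3 (0.01 log units; within the scatter) in the same series. Methoxy adds an oxygen and a hydrogen-bond acceptor that methyl lacks, yet the read-out does not separate across that exchange. No measured evidence accounts for this result.

Going by these compounds, whether an amine or a carboxylic acid on this carbon would separate from these three remains open. So does whether a longer chain such as butoxy would do so.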